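Swapping the Aryl on a Sulfonyl: Predicting Compound 3

The compounds below may be only part of what the source reports. "The series", "measured", "known", "first", "only" and "open" are said of these compounds alone.

Compound 1, `Cc1ccc(S(=O)(=O)c2cnc3cc(F)ccc3c2N2CCC(C)CC2)cc1Cl`: 93%
Compound 2, `CC1CCN(c2c(S(=O)(=O)c3cc(Cl)cc(Cl)c3)cnc3cc(F)ccc23)CC1`: 87%

Two compounds have so far been run in an assay on isolated protein for displacement of a labelled ligand from metabotropic glutamate receptor 5 (Homo sapiens), with a stated time of 60 min, tested at 1 uM; on this read-out higher numbers stand for more inhibition at the one concentration tested (going by the name of the read-out) and lower numbers for less inhibition. Compound 1 gives 93%, while compound 2 gives 87%. Compound 2 thus holds the lower of the two numbers, but the step of a number 6 percentage points lower from compound 1 to compound 2 (within the scatter) lies within the scatter, so the two cannot be told apart with confidence.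

Compound 3, `Cc1ccc(S(=O)(=O)c2cnc3cc(F)ccc3c2N2CCC(C)CC2)cc1`, is the next to be measured. It differs from compound 2 in one place: 4-methylphenyl in place of 3,5-dichlorophenyl on a sulfonyl sulfur.

Among the measured compounds shown here, the only measured step that bears on this change is a number 6 percentage points lower from compound 1 to compound 2 (within the scatter), which also exchanged one aryl group for another on the same sulfonyl sulfur and moved the read-out by less than the scatter. On that single precedent, the new exchange is expected to give a step of a number 1 percentage points higher from compound 2 to compound 3 (within the scatter), that is, no change beyond the scatter in this assay.

Compound 3 is therefore estimated at 88%, with a range from 75% to 97%.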

Compound 3, a percentage reported as inhibition, at one concentration (the size of the read-out at that concentration, not a potency): 88%
Compound 3: the middle estimate sits on the measured number at the digits printed; the measured number falls inside the stated range.
By their numbers in this assay, from the lowest: compounds 2, 3 and 1 (each within the scatter of the next).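

In this assay the exchange of 3,5-dichlorophenyl for 4-methylphenyl on the sulfonyl sulfur gives a number 1 percentage points higher from compound 2 to compound 3 (within the scatter) and so, like the earlier aryl exchange, cannot be told apart from repeat-to-repeat scatter. Among the compounds shown here, the new pair also narrows the change to one substituent for the first time: hydrogen in place of chloro on an aromatic carbon gives a number 5 percentage points lower from compound 1 to compound 3 (within the scatter) and again stays inside the scatter, so the chloro group has no effect here that this read-out can separate from noise. Nothing on hand explains why these aryl groups read alike.

Going by these compounds, all three compounds carry only chloro and methyl groups on the aryl ring, so it remains open whether an amine or a carboxylic acid on that ring, or a cyclohexyl group in place of the aryl ring on the sulfonyl sulfur, would move the number beyond the scatter. A reading at one concentration is also not a potency, so any differences among these three that a full concentration series might reveal remain unknown.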